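A few compounds are considered here, and "the series" means these few. Any claim that something is new, unique, unknown or untested is made for them only; others in the source may bear on it.

In an assay on CHO cells for displacement of a labelled ligand from C-X-C chemokine receptor type 3 (Homo sapiens), with a stated time of 60 min (a lower number here means a stronger inhibitor, a higher number a weaker inhibitor), compound 1 `Cc1cc(CN(CC2CCCC2)[C@@H](CC(=O)O)c2ccc(Cl)cc2)ccc1OCCN1C(=O)CCC1=O` gives 36 nM. Two compounds built on a different core were also measured: compound 2 `CCCN(Cc1ccc(OCCn2c(=O)ccn(C)c2=O)c(OC)c1)C(CC(=O)O)c1ccc(Cl)cc1` gives 132 nM, and compound 3 `CCCCN(Cc1ccc(OCCn2c(=O)ccn(C)c2=O)c(OC)c1)C(CC(=O)O)c1ccc(Cl)cc1` gives 69 nM. From compound 2 to compound 3 the change is methyl in place of hydrogen on a saturated chain carbon, three bonds along the chain from an amine nitrogen, and it brought a 1.9-fold lower number from compound 2 to compound 3 (0.28 log units; within the scatter). How the core of compound 1 differs from the core of compound 2 is not broken down here; the two values show a gap beyond the scatter.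

Compound 4 `CCc1cc(CN(CC2CCCC2)[C@@H](CC(=O)O)c2ccc(Cl)cc2)ccc1OCCN1C(=O)CCC1=O` has not yet been measured. It differs from compound 1 by methyl in place of hydrogen on a saturated chain carbon bound to an aromatic carbon. Among the measured compounds shown here, this is the same kind of change as the one from compound 2 to compound 3, not the same: there the new carbon sits on a saturated chain carbon, three bonds along the chain from an amine nitrogen, while here it sits on a saturated chain carbon bound to an aromatic carbon. Resting on the one earlier instance, a 1.9-fold lower number from compound 2 to compound 3 (0.28 log units; within the scatter), compound 4 is expected to show a step of a 1.2-fold lower number from compound 1 to compound 4 (0.08 log units; within the scatter) in this assay. The estimate for compound 4 is 30 nM, expected to fall between 12 nM and 80 nM.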

Compound 4, half-maximal inhibitory concentration: 31 nM
The estimate for compound 4 lay 1.0-fold (0.01 log units) below the measured number; the range from low to high includes it.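

In this assay, putting methyl in place of hydrogen on a saturated chain carbon bound to an aromatic carbon, which turns the methyl group of compound 1 into an ethyl group, gave a 1.2-fold lower number from compound 1 to compound 4 (0.06 log units; within the scatter). Set beside the earlier step on the other core, this step does not stand apart: the same change on two cores in this assay, a 1.9-fold lower number (0.28 log units; within the scatter) from compound 2 to compound 3 and a 1.2-fold lower number (0.06 log units; within the scatter) from compound 1 to compound 4, 1.6-fold (0.22 log units) apart, within the scatter of two such steps. So on both cores one added methyl left the number within the scatter, but this does not show that the change has a real, transferable effect, as neither step can be told from the scatter, there are only two instances, and the added carbon sits in a different place in each.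

Going by these compounds, whether a hydroxyl group or a fluorine atom on that same saturated chain carbon would give a step beyond the scatter remains open. It also remains open how the change would read at the same place on each core, since the two steps shown share only the kind of change.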